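The source may report more compounds than this note shows. Statements on the series, on what has been measured and on what is new or still open speak of the compounds shown alone.

Measured in an assay on isolated protein for inhibition of Amine oxidase [flavin-containing] A (Homo sapiens), read by fluorescence and spectrophotometry, with a stated time of 20 min; a lower number here means a stronger inhibitor, a higher number a weaker inhibitor:
Compound 1 `N#Cc1cc2cc(-c3ccccc3)n(O)c2cc1C#N` gives 6920 nM.
Compound 2 `N#Cc1cc2cc(-c3cccs3)n(O)c2cc1C#N` gives 11100 nM.
Compound 3 `COn1c(-c2ccccc2)c(C=O)c2cc(C#N)c(C#N)cc21` gives 522 nM.

Compound 3 stands lowest of these three numbers, and both gaps to it lie beyond the scatter. Compound 4 `COc1ccc(-c2c(C=O)c3cc(C#N)c(C#N)cc3n2OC)cc1` differs from compound 3 in one place: methoxy in place of hydrogen on an aromatic carbon. Among the compounds with values here, none of the measured steps bears directly on this change. Within the data shown here, the only single-step comparison available, a 1.6-fold higher number from compound 1 to compound 2 (0.21 log units; within the scatter), swaps one aromatic ring for another and lies within the scatter, so it offers no guide to adding a methoxy group. With nothing to point either way, the step is expected to stay within the scatter, in no clear direction: a 1.0-fold lower number from compound 3 to compound 4 (0.00 log units; within the scatter). Compound 4 is therefore estimated at 520 nM, within a range of 150 nM to 1800 nM.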

Compound 4, half-maximal inhibitory concentration: 147 nM
Estimate against measurement, compound 4: 3.5-fold (0.55 log units) above, and the stated range ends above it.
By their numbers in this assay, from the lowest: compound 4; then compound 3; then compounds 1 and 2 (each within the scatter of the next).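

In this assay, going from phenyl to 4-methoxyphenyl gives a 3.6-fold lower number from compound 3 to compound 4 (0.55 log units; beyond the scatter), a modest step, but one that makes compound 4 the stronger inhibitor. This shows that the ring carbon para to a large group can carry a methoxy group, and that the added group lowers the number rather than raising it. No measurement at hand says why the number fell.

As far as these compounds go, it remains open whether methoxy is special here, or whether a hydroxy group, a fluorine atom or an ethoxy group at the same place would give a similar step. The effect of methoxy at other carbons of this ring is also unsettled.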